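The compounds below may be only part of what the source reports. "The series", "measured", "known", "first", "only" and "open" are said of these compounds alone.

Compound 1 `Nc1ccccc1NC(=O)c1ccc(CNC(=O)c2cc3cccnc3[nH]2)cc1` is the starting point. In a functional assay on MDA-MB-231 cells (Homo sapiens) for cytotoxicity, read by MTT assay, with a stated time of 72 h (a higher number here means a weaker inhibitor, a lower number a stronger inhibitor), compound 1 gives > 100000 nM, which is a limit of the assay rather than a number, as the limit of > 100000 nM in this assay, at which 1 of the 2 values shown sits, records. Compound 2 `Nc1ccccc1NC(=O)c1ccc(NC(=O)NCc2ccc(F)nc2)cc1` gives 91000 nM in this assay, so both measured compounds sit at the weak end. Compound 3 `Nc1ccccc1NC(=O)c1ccc(CNC(=O)c2cc3cnccc3[nH]2)cc1` differs from compound 1 by a group of 9 heavy atoms (7 carbon, 2 nitrogen; one five-membered aromatic ring with 1 hetero atom, one six-membered aromatic ring with 1 hetero atom) in place of a group of 9 heavy atoms (7 carbon, 2 nitrogen; one five-membered aromatic ring with 1 hetero atom, one six-membered aromatic ring with 1 hetero atom), on a carbonyl carbon. For the measured compounds named here, no measured pair shows how such a change plays out, so nothing beyond the usual scatter is expected in either direction, and compound 3 is expected to stay weak. Compound 3 is estimated at 100000 nM, between 40000 nM and 250000 nM, which means an expected step of a number no higher from compound 1 to compound 3 (the limit leaves the size open).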

Compound 3, half-maximal inhibitory concentration: 48000 nM
Beside the measured number, compound 3's estimate is 2.1-fold (0.32 log units) above it; low and high end bracket the measured number.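

The group on the carbonyl carbon keeps the same atoms, joined differently, and this rearrangement alone gives an at least 2.0-fold lower number from compound 1 to compound 3 (0.31 log units; beyond the scatter) in this assay. For the compounds shown here, this is the first sign that at this place the arrangement of the atoms matters and not only which atoms are present, although compound 3 stays weak at 48000 nM. Compound 1 has a limit and not a number, so the full size of the step stays open: the limit of > 100000 nM in this assay, at which 1 of the 3 values shown sits.

The compounds shown leave open how a different group on this carbonyl carbon, such as a phenyl ring carrying an amine, would read. They also leave open whether any change here can move the number far from the weak end.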